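The compounds below may be only part of what the source reports. "The series", "measured", "known", "first", "only" and "open" are said of these compounds alone.

Measured compounds:
- compound 1, `O=C1N=C(N2N=C(c3ccccc3)CC2c2ccccc2O)S/C1=C1/C(=O)Nc2ccccc21`: 4770 nM
- compound 2, `O=C1N=C(N2N=C(c3ccccc3)CC2c2ccccc2O)S/C1=C1/C(=O)Nc2ccc(Br)cc21`: 800 nM
- compound 3, `COc1ccc(C2=NN(C3=NC(=O)/C(=C4\C(=O)Nc5ccccc54)S3)C(c3ccc(OC)cc3)C2)cc1`: 99600 nM

In a functional assay on cells (Cancer cell lines, Homo sapiens) for cytotoxicity, read by sulforhodamine B assay, with a stated time of 48 h (on this read-out higher numbers stand for weaker inhibition of growth and lower numbers for stronger inhibition of growth), compound 1 stands second highest of the three numbers. Its nearest neighbour is compound 2, reached by a 6.0-fold lower number from compound 1 to compound 2 (0.78 log units; beyond the scatter) through bromo in place of hydrogen on an aromatic carbon. Compound 3, which differs from compound 1 in two places, gives the highest number of the three, far beyond the scatter from compound 1.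

Compound 4, `CN(C)c1ccc(C2CC(c3ccccc3)=NN2C2=NC(=O)/C(=C3\C(=O)Nc4ccccc43)S2)cc1`, differs from compound 1 by 4-(dimethylamino)phenyl in place of 2-hydroxyphenyl on a saturated ring carbon. Within the data shown here, no measured step touches this position alone. Among the measured compounds shown here, the only compound without the 2-hydroxyphenyl group is compound 3, and its value in this assay is much weaker than that of compound 1, though a second change is mixed in. The bromo step from compound 1 to compound 2 concerns a different part of the molecule and does not bear on this change.

On that basis compound 4 is expected to give a weaker number, with a 3.1-fold higher number from compound 1 to compound 4 (0.50 log units; beyond the scatter) as the estimated step. Compound 4 is estimated at 15000 nM, in a range from 4000 nM to 60000 nM.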

Compound 4, concentration for total growth inhibition: 20300 nM
The estimate for compound 4 lay 1.4-fold (0.13 log units) below the measured number, within the range that was stated.
By their numbers in this assay, from the lowest: compound 2; then compound 1; then compound 4; then compound 3.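

In this assay, the saturated ring carbon next to the ring nitrogen now has a single-change step of its own: 4-(dimethylamino)phenyl in place of 2-hydroxyphenyl gives a 4.3-fold higher number from compound 1 to compound 4 (0.63 log units; beyond the scatter). Among these compounds, until now, the loss of 2-hydroxyphenyl could be seen only in compound 3, where a second change was mixed in; this step shows that a change at this carbon alone moves the number beyond the scatter, towards weaker inhibition of growth. Nothing available explains this shift in terms of a measured property.

The swap removes 2-hydroxyphenyl and brings in 4-(dimethylamino)phenyl in one move, so the compounds shown cannot tell whether losing the hydroxy group or adding the dimethylamino group matters more. They also leave open how a plain phenyl group at this carbon would compare, and whether the bromo step would carry over to compound 4.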